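The source may hold more compounds than are shown below. What is called first, only, known or untested is meant among the compounds shown, and "the series" means these compounds.

Measured so far:
Compound 1 `Cc1cccc(OC2CCN(c3ccc(-n4ccnc4)nn3)CC2)c1` gives 251 nM in an assay on microsomes from liver for inhibition of acyl-CoA desaturase 1 (Rattus norvegicus); a lower number here means a stronger inhibitor, a higher number a weaker inhibitor.
Compound 2 `c1cc2c(c(OC3CCN(c4ccc(-n5ccnc5)nn4)CC3)c1)CCC2` gives 10 nM.
Compound 3 `CCc1ccccc1OC1CCN(c2ccc(-n3ccnc3)nn2)CC1` gives 4 nM.

Compound 3 has the lowest number of the three. The gap to its nearest neighbour is modest, a 2.5-fold lower number from compound 2 to compound 3 (0.40 log units; beyond the scatter), while the gap to the weakest of the set is large, a 63-fold lower number from compound 1 to compound 3 (1.80 log units; beyond the scatter).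

Compound 4 `c1cn(-c2ccc(N3CCC(Oc4ccc5c(c4)CCC5)CC3)nn2)cn1` differs from compound 3 in one place: 2,3-dihydro-1H-inden-5-yl in place of 2-ethylphenyl on an oxygen on a saturated carbon. Going by the values given here, two measured steps bear on this. The first, a 63-fold lower number from compound 1 to compound 3 (1.80 log units; beyond the scatter), shows that the ethyl on the ring next to the oxygen matters a great deal, since a 3-methylphenyl without it is far weaker. The second, a 2.5-fold lower number from compound 2 to compound 3 (0.40 log units; beyond the scatter), shows that a fused five-membered ring joined as in compound 2 nearly matches the 2-ethylphenyl. Compound 4 keeps a fused ring of the same kind as compound 2 but joined through a different carbon, and it has no ethyl at all. It therefore resembles compound 1 more than compound 2 in the region that compound 3 fills with its ethyl, so a higher number in this assay is expected, probably a sizeable step rather than none.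

Compound 4 is therefore estimated to give about 80 nM in this assay, within a range of 20 nM to 320 nM, which is expected to mean a 20-fold higher number from compound 3 to compound 4 (1.30 log units; beyond the scatter).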

Compound 4, half-maximal inhibitory concentration: 62 nM
Compound 4: middle estimate off by 1.3-fold (0.11 log units), on the high side, within the range that was stated.
By their numbers in this assay, from the lowest: compound 3; then compound 2; then compound 4; then compound 1.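

The two groups 2,3-dihydro-1H-inden-4-yl and 2,3-dihydro-1H-inden-5-yl differ in their names only by the number of the carbon that carries the oxygen, yet in this assay this change gives a 6.2-fold higher number from compound 2 to compound 4 (0.79 log units; beyond the scatter) and so the point of attachment matters here, not just the presence of the two rings. The new group sits in the middle of the series at this oxygen on a saturated carbon: replacing 2-ethylphenyl gives a 16-fold higher number from compound 3 to compound 4 (1.19 log units; beyond the scatter) while replacing 3-methylphenyl gives a 4.0-fold lower number from compound 1 to compound 4 (0.61 log units; beyond the scatter) and both steps lie beyond the usual scatter. No measurement is available that explains why these groups rank in this order.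

The compounds shown carry only carbon-based groups on this ring, so it remains open how a methoxy group or a fluorine in place of the ethyl of compound 3 would compare. A longer chain, such as the propyl of a 2-propylphenyl group, would show whether the low number of compound 3 holds as the chain grows.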